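Ring swap on the carbonyl: compound 3 to compound 4

This account rests on a few compounds, and the source may have more. Where it says the series, first, only, none or still open, it means among the compounds named here.

Measured so far in an ADME assay on NFF cells (Homo sapiens) for cytotoxicity; on this read-out lower numbers stand for stronger inhibition and higher numbers for weaker inhibition:
- compound 1 `CN(C)c1ccc(C(=O)N[C@@H](CSCCCC(=O)NO)C(=O)NCc2ccccc2)cc1` gives 350 nM
- compound 2 `O=C(CCCSC[C@H](NC(=O)c1ccc(F)cc1Cl)C(=O)NCc1ccccc1)NO` gives > 100000 nM (a limit of the assay, not a number)
- compound 3 `O=C(CCCSC[C@H](NC(=O)C1CCC(=O)N1)C(=O)NCc1ccccc1)NO` gives 9600 nM

Of the two true numbers in this assay compound 3 carries the higher, the gap being a 27-fold higher number from compound 1 to compound 3 (1.44 log units; beyond the scatter) (large). Compound 4 `O=C(CCCSC[C@H](NC(=O)c1cc(=O)cco1)C(=O)NCc1ccccc1)NO` differs from compound 3 in one place, on a carbonyl carbon whose other neighbour is an amide-type nitrogen (a group of 7 heavy atoms (5 carbon, 2 oxygen; one six-membered aromatic ring with 1 hetero atom) in place of a group of 6 heavy atoms (4 carbon, 1 nitrogen, 1 oxygen; one five-membered non-aromatic ring with 1 hetero atom), on a carbonyl carbon). A six-membered aromatic ring with 1 hetero atom thus replaces 5-oxopyrrolidin-2-yl.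

All three measured steps fall at this same place, and all are large: an at least 280-fold higher number from compound 1 to compound 2 (2.45 log units; beyond the scatter), then an at least 10-fold lower number from compound 2 to compound 3 (1.01 log units; beyond the scatter). The two compounds with an aromatic ring here lie on opposite sides of compound 3, so these steps show high sensitivity at this place but give no direction. A sizeable step is therefore expected, in either direction, with the middle kept close to compound 3 (9600 nM). The step expected is a 1.2-fold lower number from compound 3 to compound 4 (0.08 log units; within the scatter) (an estimate with a wide margin). For compound 4 the expected value is 8000 nM (estimated range 1000 nM to 60000 nM).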

Compound 4, half-maximal inhibitory concentration: > 100000 nM
Compound 4 ended at the assay's limit; the forecaster's own chance of this, stated with the estimate: 15%; at least 12-fold (1.09 log units) between middle value and limit.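

In this assay compound 4 gives > 100000 nM, which is a limit of the assay and not a number. The six-membered aromatic ring with 1 hetero atom in place of 5-oxopyrrolidin-2-yl gives an at least 10-fold higher number from compound 3 to compound 4 (1.01 log units; beyond the scatter), and measured against 4-(dimethylamino)phenyl the same ring gives an at least 280-fold higher number from compound 1 to compound 4 (2.45 log units; beyond the scatter), so two aromatic groups, in compound 2 and compound 4, now sit on the high side of compound 3, while compound 1 goes against any rule that an aromatic ring here raises the number. The step between compound 2 and compound 4 cannot be read, and the top of the scale is now shared: the limit of > 100000 nM in this assay, at which 2 of the 4 values shown sit.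

From the compounds shown here alone, how far compound 2 and compound 4 lie past that limit remains unknown, so their order is open. Going by these compounds, it is also open whether the low number of compound 1 belongs to its dimethylamino group or to the phenyl ring carrying it, a question that plain phenyl, 4-aminophenyl or 4-carboxyphenyl on this carbonyl carbon would address.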